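Cytotoxicity Sits at the Limit Across Three Biaryl Amides

The source may report more compounds than this note shows. Statements on the series, on what has been measured and on what is new or still open speak of the compounds shown alone.

Compound 2 `CC(C)N(Cc1cccc(OCCCCCC(=O)O)c1)C(=O)c1ccc(-c2ccncc2)cc1` was examined in an ADME assay on HEK293 cells (Homo sapiens) for cytotoxicity, read by CellTiter-Glo and resazurin assay, with a stated time of 72 h; on this read-out higher numbers stand for an effect only at larger amounts of compound and lower numbers for an effect already at smaller amounts. In this read-out compound 2 gives only a limit, > 26000 nM. Compound 1 `CC(=O)Nc1cccc(-c2ccc(C(=O)N(Cc3cccc(OCCCCCC(=O)O)c3)C(C)C)cc2)c1` likewise gives only a limit, > 26000 nM. Compound 3 `CC(C)N(Cc1cccc(OCCCCCC(=O)O)c1)C(=O)c1ccc(-c2ccoc2)cc1` also gives only a limit, > 26000 nM. All three measured values therefore sit together: the limit of > 26000 nM in this assay, at which 3 of the 3 values shown sit. Where compound 2 stands on the numbers shown is thus the limit of the assay, and no ordering among compounds 1, 2 and 3 can be read from them.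

Compound 4 `COc1cc(F)cc(-c2ccc(C(=O)N(Cc3cccc(OCCCCCC(=O)O)c3)C(C)C)cc2)c1` has not yet been measured. It differs from compound 2 by 3-fluoro-5-methoxyphenyl in place of pyridin-4-yl on an aromatic carbon. The measured steps that bear on this change are a step that the two limits leave unreadable from compound 2 to compound 3 and a step that the two limits leave unreadable from compound 1 to compound 2, and the step that the two limits leave unreadable from compound 1 to compound 3 likewise stands between two limits, so none of them yields a size. Exchanging the group at this position has so far not produced a value beneath the limit, and the three compounds give no basis to expect that 3-fluoro-5-methoxyphenyl will do otherwise. Compound 4 is therefore expected to give 30000 nM, with a range from 15000 nM to 80000 nM, most likely again only as a limit. Compound 4 is thus estimated to show a step that the limit leaves unreadable from compound 2 to compound 4, none beyond the scatter.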

Compound 4, half-maximal effective concentration: > 26000 nM
Compound 4 gave a limit, no number; the forecaster's own chance of this, stated with the estimate: 85%; the middle value is on the limit's open side.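

In this assay, going by these compounds alone, compound 4 gives > 26000 nM, which is a limit, so the steps linking compound 4 with compounds 1, 2 and 3 cannot be read and no new step emerges. All four compounds stand together: the limit of > 26000 nM in this assay, at which 4 of the 4 values shown sit.

The compounds shown leave open how compounds 1, 2, 3 and 4 would order, and whether any group at this position would give a number rather than a limit.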